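A few compounds are considered here, and "the series" means these few. Any claim that something is new, unique, unknown or untested is made for them only; others in the source may bear on it.

Measured in a functional assay on NCI-H226 cells (Homo sapiens) for inhibition, read by sulforhodamine B assay, with a stated time of 48 h; on this read-out higher numbers stand for weaker inhibition of growth and lower numbers for stronger inhibition of growth:
- compound 1 `CCCCCCCCCCCC[C@@H](O)[C@H]1CC[C@H]([C@H](O)CCCCCCCCCCNC(=O)c2ccnn2C)O1`: 40700 nM
- compound 2 `CCCCCCCCCCCC[C@@H](O)[C@H]1CC[C@H]([C@H](O)CCCCCCCCCCN(C)C(=O)c2ccnn2C)O1`: 9770 nM

Compound 2 has the lower of the two numbers, at 9770 nM. The next compound is compound 3 `CCCCCCCCCCCC[C@@H](O)[C@H]1CC[C@H]([C@H](O)CCCCCCCCCCNCc2ccnn2C)O1`, with this change: ((1-methyl-1H-pyrazol-5-yl)methyl)amino in place of methyl((1-methyl-1H-pyrazol-5-yl)carbonyl)amino on a saturated chain carbon, ten or more bonds along the chain from an oxygen on a saturated carbon and a saturated ring carbon. Among the compounds with values here, the only measured step that bears on it is a 4.2-fold lower number from compound 1 to compound 2 (0.62 log units; beyond the scatter), a modest step for methyl in place of hydrogen on an amide-type nitrogen. Within the data shown here, no measured compound shows what losing the carbonyl does, so no direction can be favoured. In this assay the expected result is a 1.1-fold lower number from compound 2 to compound 3 (0.04 log units; within the scatter), with no shift expected beyond the scatter. For compound 3 the estimated value is 9000 nM, with an expected range of 2500 nM to 30000 nM.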

Compound 3, concentration for 50% growth inhibition: 3310 nM
Compound 3: the middle estimate sits 2.7-fold (0.43 log units) above what was measured, within the range that was stated.
By their numbers in this assay, from the lowest: compound 3; then compound 2; then compound 1.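

In this assay the carbonyl is not required at this position: (1-methyl-1H-pyrazol-5-yl)methyl in place of (1-methyl-1H-pyrazol-5-yl)carbonyl on the amine nitrogen gives a 12-fold lower number from compound 1 to compound 3 (1.09 log units; beyond the scatter), the largest step in the series. Measured against the methylated amide, the amine still gives a 3.0-fold lower number from compound 2 to compound 3 (0.47 log units; beyond the scatter). No available evidence accounts for either step.

As far as these compounds go, whether a methyl on the amine nitrogen of compound 3, giving a tertiary amine, shifts the number further remains open. From the compounds shown here alone, the effect of a phenyl ring in place of the 1-methyl-1H-pyrazol-5-yl group on this amine is also open.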